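The source may hold more compounds than are shown below. What is called first, only, known or untested is meant among the compounds shown, and "the series" means these compounds.

Measured in a functional assay on MV4-11 cells (Homo sapiens) for inhibition, read by resazurin assay, with a stated time of 72 h; a lower number here means a stronger inhibitor of growth, a higher number a weaker inhibitor of growth:
- Compound 1 `Cc1ccsc1-c1cncc(Cl)c1N1CCC2(CCNC2=O)CC1`: 910 nM
- Compound 2 `O=Cc1cscc1-c1cncc(Cl)c1N1CCC2(CCNC2=O)CC1`: 27100 nM

Compound 2 holds the higher of the two numbers. Compound 3 `O=C1NCCC12CCN(c1c(Cl)cncc1-c1cnn(C(F)F)c1)CC2` keeps the shared core and changes one group: 1-(difluoromethyl)-1H-pyrazol-4-yl in place of 4-formylthiophen-3-yl on an aromatic carbon. The new group sits on an aromatic carbon of a six-membered aromatic ring with 1 nitrogen, ortho to a large group.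

Among the measured compounds shown here, only one measured step bears on this change: a 30-fold higher number from compound 1 to compound 2 (1.47 log units; beyond the scatter). It is a large step from a swap of the same kind, so the number in this assay can clearly move with this group. For the measured compounds named here, no measured compound carries a pyrazole, so the size of the new step is poorly constrained. A step toward a lower number is expected, and it would probably stop short of compound 1. The expected change is a 7.7-fold lower number from compound 2 to compound 3 (0.89 log units; beyond the scatter). For compound 3 the estimated value is 3500 nM, with an expected range of 800 nM to 15000 nM.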

Compound 3, concentration for 50% growth inhibition: 6140 nM
Beside the measured number, compound 3's estimate is 1.8-fold (0.24 log units) below it; the range from low to high includes it.
By their numbers in this assay, from the lowest: compound 1; then compound 3; then compound 2.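

In this assay, the place on an aromatic carbon of a six-membered aromatic ring with 1 nitrogen also accepts a five-membered aromatic ring with 2 hetero atoms, with a 4.4-fold lower number from compound 2 to compound 3 (0.64 log units; beyond the scatter). The 1-(difluoromethyl)-1H-pyrazol-4-yl group does not match the 3-methylthiophen-2-yl group, however, giving a 6.7-fold higher number from compound 1 to compound 3 (0.83 log units; beyond the scatter), so compound 3 falls between the two thiophene compounds and a thiophene ring alone does not fix the number. No supporting measurement bears on either step.

Still open, from the compounds shown here alone, is whether the pyrazole ring or its difluoromethyl group sets the number of compound 3, a question that a methyl group on the same pyrazole nitrogen would address. A methylthiophene attached as in compound 2 would likewise separate the effect of the formyl group from that of the ring attachment.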